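Replacing the thioester of compound 3 with a methyloxazole

This account rests on a few compounds, and the source may have more. Where it says the series, first, only, none or still open, it means among the compounds named here.

Compound 3 `CC1=C(C(=O)SC(C)C)C(c2ccco2)NC(=O)N1` gives 1% in an assay on membranes from HeLa cells for displacement of a labelled ligand from adenosine receptor A3 (Homo sapiens), read by scintillation counting, with a stated time of 180 min, tested at 1 uM (on this read-out higher numbers stand for more inhibition at the one concentration tested (going by the name of the read-out) and lower numbers for less inhibition), the lowest of the three numbers. Compound 1 `CC1=C(C(=O)C2CC2)C(c2ccco2)NC(=O)N1` gives 7% and compound 2 `CC1=C(C(=O)CC(C)C)C(c2ccco2)NC(=O)N1` gives 31% in this assay. The step of a number 6 percentage points lower from compound 1 to compound 3 (within the scatter) lies within the scatter, whereas a number 30 percentage points lower from compound 2 to compound 3 (beyond the scatter) and a number 24 percentage points higher from compound 1 to compound 2 (beyond the scatter) are modest steps. Compound 4 `CC1=C(c2ncc(C)o2)C(c2ccco2)NC(=O)N1` differs from compound 3 thus: 5-methyl-1,3-oxazol-2-yl in place of (isopropylsulfanyl)carbonyl on a double-bonded ring carbon. For the measured compounds named here, no measured step exchanges the (isopropylsulfanyl)carbonyl group for an aromatic ring; the measured steps only vary the group on the carbonyl carbon, and their swings are modest. The step of a number 9 percentage points higher from compound 3 to compound 4 (within the scatter) is therefore expected to stay small. Compound 4 is estimated at 10%, with a range from 0% to 35%.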

Compound 4, a percentage reported as inhibition, at one concentration (the size of the read-out at that concentration, not a potency): 4%
Compound 4: the middle estimate sits 6 percentage points above what was measured; low and high end bracket the measured number.
By their numbers in this assay, from the lowest: compounds 3, 4 and 1 (each within the scatter of the next); then compound 2.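

The result shows that a group without a carbonyl, here an aromatic ring, can occupy this double-bonded ring carbon without moving the number beyond the scatter of the low-reading compounds in this assay (a number 3 percentage points higher from compound 3 to compound 4 (within the scatter); a number 3 percentage points lower from compound 1 to compound 4 (within the scatter)). Only isobutylcarbonyl stands apart from 5-methyl-1,3-oxazol-2-yl (a number 27 percentage points lower from compound 2 to compound 4 (beyond the scatter)). Nothing available explains this outcome. Still open, from the compounds shown here alone, is whether a phenyl ring, or an oxazole carrying a longer chain in place of its methyl, would reach the number of compound 2 31%. Going by these compounds, an amine or a carboxylic acid at this carbon also remains open.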